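Trading Ethyl for Propylsulfanyl in a Sodium/Hydrogen Exchanger Series

The source may report more compounds than this note shows. Statements on the series, on what has been measured and on what is new or still open speak of the compounds shown alone.

Of the compounds shown here, three built on one shared core have been tested in a functional assay for inhibition of sodium/hydrogen exchanger (Oryctolagus cuniculus); a higher number here means a weaker inhibitor, a lower number a stronger inhibitor. Compound 2 `CCc1cc(C)c(C(=O)N=C(N)N)cc1S(C)(=O)=O` gives 4.8 nM in this assay, the lowest number of the three and therefore the strongest inhibitor of this small set. Compound 3 `Cc1cc(Br)c(C(=O)N=C(N)N)cc1S(C)(=O)=O` gives 70 nM, and compound 1 `CCN(CC)Cc1cc(Br)c(S(C)(=O)=O)cc1C(=O)N=C(N)N` gives 9500 nM; both of these gaps to compound 2 lie well beyond the usual scatter of repeated measurements.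

Compound 4 `CCCSc1cc(C)c(C(=O)N=C(N)N)cc1S(C)(=O)=O` has not yet been measured. It differs from compound 2 in a single place: propylsulfanyl in place of ethyl on an aromatic carbon. The propylsulfanyl group sits ortho to the methylsulfonyl group, exactly where the ethyl group stood before.

Among the compounds with values here, no pair of measured compounds differs in only this way, so the size of the effect cannot be read off directly. Because compound 2 already stands at 4.8 nM, a small step toward weaker inhibition, only modestly beyond the scatter, is expected in this assay, and the expected step is a 2.5-fold higher number from compound 2 to compound 4 (0.40 log units; beyond the scatter). Compound 4 is estimated at 12 nM, with a likely range from 3 nM to 50 nM.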

Compound 4, half-maximal inhibitory concentration: 6.8 nM
Beside the measured number, compound 4's estimate is 1.8-fold (0.25 log units) above it; measured number inside the range.
By their numbers in this assay, from the lowest: compounds 2 and 4 (each within the scatter of the next); then compound 3; then compound 1.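

Placing propylsulfanyl in place of ethyl on this aromatic carbon, ortho to the methylsulfonyl group, gives a 1.4-fold higher number from compound 2 to compound 4 (0.15 log units; within the scatter) in this assay, so the two groups cannot be told apart here. Within the data shown here, this position therefore accepts a chain of 4 heavy atoms, one of them sulfur, and compound 4 stays in the same low range at 6.8 nM, which the earlier compounds could not show. No measurement on hand explains why the two groups match.

As far as these compounds go, whether the sulfur itself matters remains open, and a comparison with butyl or propoxy at this carbon would address that. It is also unknown how far this acceptance extends, for instance to a longer chain such as hexylsulfanyl, to an amine or to a carboxylic acid.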